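Shortened thioether linker in an adenosine-indole series

A few compounds are considered here, and "the series" means these few. Any claim that something is new, unique, unknown or untested is made for them only; others in the source may bear on it.

Among the compounds with values here, compound 1 `C[S+](CCCc1c[nH]c2ccccc12)CCC(N)C(=O)O` is the only acyclic amino-acid member here. In an assay on isolated protein (Oryctolagus cuniculus) for inhibition of indolethylamine N-methyltransferase (Homo sapiens), read by radioligand binding (a lower number here means a stronger inhibitor, a higher number a weaker inhibitor), compound 1 reaches only the limit > 1000000 nM, not a number. Compound 2 `Nc1ncnc2c1ncn2[C@@H]1O[C@H](CSCCCCc2c[nH]c3ccccc23)[C@@H](O)[C@H]1O` carries the indole on a four-carbon chain from the thioether sulfur of a nucleoside. In this assay compound 2 likewise stops at the limit > 1000000 nM. Both values thus sit at the limit of > 1000000 nM in this assay, at which 2 of the 2 values shown sit, so compound 2 stands nowhere above the rest; no ranking is possible. Compound 3 `Nc1ncnc2c1ncn2[C@@H]1O[C@H](CSCCCc2c[nH]c3ccccc23)[C@@H](O)[C@H]1O` differs from compound 2 in one place: 1H-indol-3-yl in place of (1H-indol-3-yl)methyl on a saturated chain carbon, three bonds along the chain from a sulfur. Within the data shown here, no measured step between compounds is available, so the expected size for this change rests only on the two limits. The step from compound 2 to compound 3 is expected to be none beyond the scatter, as a number no higher from compound 2 to compound 3 (the limit leaves the size open), most probably ending again at a limit. Compound 3 is therefore estimated at 1000000 nM, within 300000 nM to 3000000 nM.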

Compound 3, half-maximal inhibitory concentration: > 1000000 nM
Compound 3 was reported as a limit; the forecaster's own chance of this, stated with the estimate: 75%; the middle value sits exactly at the limit.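

Compound 3 in this assay gives > 1000000 nM as a limit and not a number, so the step from compound 2 to compound 3 cannot be read: the limit of > 1000000 nM in this assay, at which 3 of the 3 values shown sit. The compounds shown leave open whether any change to the chain brings a measurable value.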